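This account rests on a few compounds, and the source may have more. Where it says the series, first, only, none or still open, it means among the compounds named here.

Of the compounds shown here, two have been measured in a functional assay on MCF7 cells (Homo sapiens) for cytotoxicity, read by MTT assay, with a stated time of 24 h, tested at 1.6 ug/mL; a lower number here means a weaker effect, a higher number a stronger effect of the compound at the concentration tested. Compound 1 `Cn1c(-c2ccc(NC(=O)CSc3nc4ccccc4s3)cc2)nc(-c2ccccc2)c1-c1ccccc1` gives 2.1%. Compound 2 `CN(C)/C=C/N1CCN(CC(=O)Nc2ccc(-c3nc(-c4ccccc4)c(-c4ccccc4)n3C)cc2)CC1` gives 1.9%. Among the compounds with values here, the only measured step, a number 0.2 percentage points lower from compound 1 to compound 2 (within the scatter), exchanges the group on the saturated chain carbon bound to the carbonyl carbon and leaves the read-out where it was. On these two numbers compound 2 stands within the scatter of compound 1, so no order between them can be claimed; both values lie near the floor of the read-out.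

Compound 3 `Cc1ccc(CN2CCN(CC(=O)Nc3ccc(-c4nc(-c5ccccc5)c(-c5ccccc5)n4C)cc3)CC2)cc1` is not yet measured. Its change from compound 2 is 4-methylbenzyl in place of 2-(dimethylamino)ethenyl on an amine nitrogen in a ring. Within the data shown here, the single measured step bears on it only loosely: it shows that exchanging the group at that end of the chain moved nothing beyond the scatter. For compound 3 a step of a number 0.1 percentage points higher from compound 2 to compound 3 (within the scatter) is therefore expected, none beyond the scatter. The estimate for compound 3 is 2%, in the range -6% to 12%.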

Compound 3, a percentage reported as activity, at one concentration (the size of the read-out at that concentration, not a potency): 19.3%
The estimate for compound 3 lay 17.3 percentage points below the measured number; measured number outside the range, above it.
By their numbers in this assay, from the lowest: compounds 2 and 1 (each within the scatter of the next); then compound 3.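

In this assay, the group on the amine nitrogen in the ring proves able to move the read-out: 4-methylbenzyl in place of 2-(dimethylamino)ethenyl gives a number 17.4 percentage points higher from compound 2 to compound 3 (beyond the scatter). Within the data shown here, this is the first step beyond the scatter, so the flat result for compounds 1 and 2 does not hold for every group at this end of the chain. Nothing available accounts for the rise, and the data give no cause for it.

The compounds shown leave open whether the rise goes with the six-membered aromatic ring of 4-methylbenzyl or with its methyl group, a question that a plain benzyl or a cyclohexylmethyl on the same nitrogen would address. From the compounds shown here alone, because the read-out comes from one concentration, potency also remains open.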